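Ethylamide for Ester: Expected Cytotoxicity of Compound 4

A few compounds are considered here, and "the series" means these few. Any claim that something is new, unique, unknown or untested is made for them only; others in the source may bear on it.

Compound 1 `CCCCCC[C@H]1C[C@@H](O)[C@@H](O)C1`, compound 2 `COC(=O)/C=C/[C@H]1C[C@@H](O)[C@@H](O)C1`, compound 3 `NC(=O)/C=C/[C@H]1C[C@@H](O)[C@@H](O)C1` and compound 4 `CCNC(=O)/C=C/[C@H]1C[C@@H](O)[C@@H](O)C1` share one core. In an ADME assay on S2 cells (Drosophila melanogaster) for cytotoxicity, read by MTT assay (a higher number here means that more compound is needed for the effect, a lower number that less compound is needed), compound 1 gives 110000 nM. Compound 2 reaches only a limit in this assay, namely > 350000 nM. Compound 3 likewise reaches only a limit in this assay, namely > 250000 nM. The step from compound 2 to compound 3 is a step that the two limits leave unreadable from compound 2 to compound 3, so its size cannot be read. Compound 4 differs from compound 2 by ethylamino in place of methoxy on a carbonyl carbon. Going by the values given here, the one step at this place is unreadable, so no shift beyond the scatter is expected in this assay. Compound 4 is expected near the limit, at about 350000 nM (from 150000 nM to 800000 nM). The expected step is a number no higher from compound 2 to compound 4 (the limit leaves the size open), within the scatter.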

Compound 4, half-maximal effective concentration: > 250000 nM
Compound 4 ended at the assay's limit; the forecaster's own chance of this, stated with the estimate: 70%; the middle value does not contradict the limit.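

In this assay compound 4 gives > 250000 nM as a limit, so the steps from compound 2 and from compound 3 to compound 4 cannot be read. The compounds shown leave open whether in this assay methoxy, amino and ethylamino on a carbonyl carbon differ at all.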